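The source may hold more compounds than are shown below. What is called first, only, known or untested is meant among the compounds shown, and "the series" means these compounds.

The measured compounds in a functional assay on HeLa cells (Homo sapiens) for antiproliferative activity, read by CCK-8 assay, with a stated time of 72 h, tested at 2 uM; a higher number here means a stronger effect of the compound at the concentration tested, a lower number a weaker effect:
compound 1, `Nc1ccccc1NC(=O)c1ccc(CSC(=S)N2CCCc3ccccc32)cc1`, gives 26.1%
compound 2, `Nc1ccccc1NC(=O)c1ccc(CSC(=S)N2CCN(c3ccc(F)cc3)CC2)cc1`, gives 60.8%
compound 3, `CC1CCCCN1C(=S)SCc1ccc(C(=O)Nc2ccccc2N)cc1`, gives 45.5%

Compound 2 stands highest of the three numbers in this assay; compound 3 comes nearest and compound 1 lies furthest, and both of those gaps are beyond the scatter. Among the measured compounds shown here, the only step recorded between measured compounds that differ in a single place is a number 19.4 percentage points higher from compound 1 to compound 3 (beyond the scatter), a change on the thiocarbonyl carbon.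

Compound 4, `Nc1ccccc1NC(=O)c1ccc(CSC(=S)N2CCN(c3ccccc3F)CC2)cc1`, differs from compound 2 in another place: 2-fluorophenyl in place of 4-fluorophenyl on an amine nitrogen in a ring. For the measured compounds named here, no measured pair in this set alters the group on the amine nitrogen in the ring, so the one recorded step, which concerns a different part of the molecule, gives no direct guide to the size or direction of the present change. The data hold nothing on moving the fluorine within the phenyl ring, and the two groups exchanged are counted alike in atoms, donors and acceptors.

Compound 4 is therefore expected to stay close to compound 2 in this assay. The expected step is a number 6.8 percentage points lower from compound 2 to compound 4 (within the scatter), which is within the scatter. The estimated value for compound 4 is 54%, in a range from 38% to 68%.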

Compound 4, a percentage reported as inhibition, at one concentration (the size of the read-out at that concentration, not a potency): 17.5%
For compound 4 the middle estimate is 36.5 percentage points above the measured one; the whole stated range lies above it.
By their numbers in this assay, from the lowest: compounds 4 and 1 (each within the scatter of the next); then compound 3; then compound 2.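

In this assay, the step of a number 43.3 percentage points lower from compound 2 to compound 4 (beyond the scatter) shows that this place on the amine nitrogen in a ring is sensitive to the exchange of 4-fluorophenyl for 2-fluorophenyl, even though the two groups have the same atoms and the same counts of hydrogen-bond donors and acceptors. The earlier step of a number 19.4 percentage points higher from compound 1 to compound 3 (beyond the scatter) replaced one whole group on the thiocarbonyl carbon with another, whereas here the same atoms are only joined differently and the read-out still moves well beyond the scatter. No measurement available here accounts for this loss, so the result stands as an observation without an explanation.

The two fluorophenyl compounds alone do not show whether the fall follows from having any group at the place held by fluorine in the 2-fluorophenyl ring, or from fluorine in particular. Going by these compounds, a plain phenyl group, or a chlorine or methyl group carried on the phenyl ring in place of the fluorine, would be needed to separate these readings, and whether the same exchange behaves alike on other parts of the series remains open.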